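A few compounds are considered here, and "the series" means these few. Any claim that something is new, unique, unknown or untested is made for them only; others in the source may bear on it.

In a functional assay on the whole organism with Rattus norvegicus as the target, with a stated time of 4 h, at a dose of 40 mg/kg by the intraperitoneal route (on this read-out higher numbers stand for more inhibition at the one dose given (going by the name of the read-out) and lower numbers for less inhibition), compound 1 `Cc1cn2cccc(OCc3ccccc3)c2n1` gives 62%, compound 2 `CC(=O)c1c(C)nc2c(OCc3ccccc3)cccn12` gives 57% and compound 3 `CCCCC(=O)OCc1c(C)nc2c(OCc3ccccc3)cccn12` gives 45%. Compound 3 stands lowest of the three numbers: the step of a number 17 percentage points lower from compound 1 to compound 3 (beyond the scatter) and the step of a number 12 percentage points lower from compound 2 to compound 3 (beyond the scatter) both lie beyond the scatter, whereas a number 5 percentage points lower from compound 1 to compound 2 (within the scatter) stays within it.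

Compound 4 `Cc1nc2c(OCc3ccccc3)cccn2c1COC(=O)N(C)C` differs from compound 3 by dimethylamino in place of butyl on a carbonyl carbon. Among the measured compounds shown here, no measured step tests this exchange: the two steps that reach compound 3 place the whole ((butylcarbonyl)oxy)methyl group where hydrogen or acetyl stood, and the carbonyl substituent itself has not been varied. What the three measured compounds do show is that replacements on the aromatic carbon move the read-out in this assay by modest amounts at most, so for the smaller change at the carbonyl carbon no step beyond the scatter is expected, no change at the digits printed from compound 3 to compound 4 (within the scatter). Compound 4 is therefore estimated to give 45%, with a range from 30% to 60%.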

Compound 4, a percentage reported as inhibition, in the whole organism at one dose (the size of the read-out at that dose, not a potency): 75%
For compound 4 the middle estimate is 30 percentage points below the measured one; measured number outside the range, above it.
By their numbers in this assay, from the lowest: compound 3; then compounds 2 and 1 (each within the scatter of the next); then compound 4.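

In this assay, among the compounds shown here, the group on the carbonyl carbon matters and not only the replacement on the aromatic carbon: dimethylamino in place of butyl gives a number 30 percentage points higher from compound 3 to compound 4 (beyond the scatter), a larger step than any among the earlier compounds. Among the replacements shown on that aromatic carbon, ((dimethylcarbamoyl)oxy)methyl alone gives a higher number, with a number 13 percentage points higher from compound 1 to compound 4 (beyond the scatter) and a number 18 percentage points higher from compound 2 to compound 4 (beyond the scatter), whereas ((butylcarbonyl)oxy)methyl gives a number 17 percentage points lower from compound 1 to compound 3 (beyond the scatter) and acetyl stays within the scatter of hydrogen. Nothing available explains this reversal.

Going by these compounds, it remains open whether the gain requires nitrogen on the carbonyl carbon or would also follow from a shorter chain, which methyl in place of butyl would test. Diethylamino on the same carbonyl carbon, or a free hydroxymethyl on the aromatic carbon, would show how far the result extends.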